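Swapping an Aromatic Amide Cap and Expected Cell Tolerance

This account rests on a few compounds, and the source may have more. Where it says the series, first, only, none or still open, it means among the compounds named here.

Three measured compounds share one core. Compound 1 `O=C(Nc1ncc(C(Oc2ccc3cc(Br)ccc3c2)c2ccc(Cl)cc2)s1)c1cccs1` gives "not toxic" (no number reported) in an ADME assay on HepG2 2.2.15 cells (Homo sapiens) for cytotoxicity; a lower number here means that less compound is tolerated, a higher number that more compound is tolerated. Compound 2 `CCOC(=O)CCCNc1ncc(C(Oc2ccc3cc(Br)ccc3c2)c2ccc(Cl)cc2)s1` likewise gives "not toxic" (no number reported). For compound 3 `COc1ccc(C(=O)Nc2ncc(C(Oc3ccc4cc(Br)ccc4c3)c3ccc(Cl)cc3)s2)cc1` only a limit of the assay is recorded, > 50000 nM. Compound 3 thus stands at the upper edge of what this assay reports, with no single number beside it. Compound 4 `Cc1noc(C)c1C(=O)Nc1ncc(C(Oc2ccc3cc(Br)ccc3c2)c2ccc(Cl)cc2)s1` differs from compound 3 in one place: 3,5-dimethyl-1,2-oxazol-4-yl in place of 4-methoxyphenyl on a carbonyl carbon. Going by the values given here, no measured pair shows what such a change does here, so no step beyond the usual scatter is expected in this assay in either direction. Compound 4 is therefore expected to give 60000 nM, within 20000 nM to 200000 nM. The step this estimate means, a step that the limit leaves unreadable from compound 3 to compound 4, is expected to stay within the scatter, given that compound 3 already sits at the limit of > 50000 nM in this assay, at which 1 of the 3 values shown sits.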

Compound 4, half-maximal cytotoxic concentration: "not toxic" (no number reported)
Compound 4 has no reported number here; the estimate stays without a comparison.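

No step can be read from compound 3 to compound 4: compound 3 has only a limit, and compound 4 has no number. The compounds shown leave open at what concentration any of them turns toxic in this assay.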